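A few compounds are considered here, and "the series" means these few. Any claim that something is new, unique, unknown or untested is made for them only; others in the source may bear on it.

This study asks how strongly a small set of hydrazone compounds hold back the growth of a brain-tumour cell line in a functional assay on U-87MG ATCC cells for inhibition, with U-87 MG (Homo sapiens) as the target, read by MTT assay, with a stated time of 48 h; a higher number here means a weaker inhibitor, a lower number a stronger inhibitor. Compound 1 `COc1cc(/C=N/Nc2nc(-c3ccc(Br)cc3)cs2)cc(Br)c1OC`, which carries one bromo on each of its two outer rings, gives 27900 nM in this assay. Compound 2 `COc1cc(/C=N/Nc2nc(-c3ccc(C(F)(F)F)cc3)cs2)c(Br)c(Br)c1OC` instead carries a trifluoromethyl group and two bromo groups. In this assay compound 2 reaches only > 100000 nM, which is a limit of the assay rather than a number, so it stands at the limit of > 100000 nM in this assay, at which 1 of the 2 values shown sits. Compound 3 `COc1cc(/C=N/Nc2nc(-c3ccc(C(F)(F)F)cc3)cs2)cc(Br)c1OC` has not yet been measured; the change from compound 2 is hydrogen in place of bromo on an aromatic carbon. Within the data shown here, no measured pair shows what this change does, and a limit hides any gain from the step. The expected step is an at least 2.5-fold lower number from compound 2 to compound 3 (0.39 log units; beyond the scatter). Compound 3 is estimated at 40000 nM, likely between 15000 nM and 150000 nM.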

Compound 3, half-maximal inhibitory concentration: 41000 nM
Compound 3: middle estimate off by 1.0-fold (0.01 log units), on the low side; low and high end bracket the measured number.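

In this assay, hydrogen in place of bromo at this position on the methoxy-bearing ring gives an at least 2.4-fold lower number from compound 2 to compound 3 (0.38 log units; beyond the scatter), so the extra bromo is not needed for the activity seen, and losing it brings a real gain. Going by these compounds, the true size of this step stays unknown, because compound 2 marks only a lower bound: the limit of > 100000 nM in this assay, at which 1 of the 3 values shown sits. On the other outer ring, trifluoromethyl in place of bromo gives a 1.5-fold higher number from compound 1 to compound 3 (0.17 log units; within the scatter), so these two groups cannot be told apart in this assay.

On these data alone, it remains open whether a different group at the position that lost its bromo, such as an amine or a carboxylic acid, would do better than hydrogen. As far as these compounds go, it is also open what would happen if the remaining bromo on that ring were replaced by hydrogen.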